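The compounds below may be only part of what the source reports. "The series", "measured", "known", "first", "only" and "open" are said of these compounds alone.

Measured so far in a physicochemical assay for solubility, measured as kinetic solubility, with a stated time of 24 h, at pH 7.4; a lower number here means a less soluble compound, a higher number a more soluble compound
compound 1 `O=C(NCc1ccc(S(=O)(=O)c2cc(F)cc(F)c2)cc1)c1cc2ccncc2o1` gives 5900 nM
compound 2 `O=C(NCc1ccc(S(=O)(=O)c2cc(F)cc(F)c2)cc1)c1cc2cnccc2[nH]1` gives 1600 nM
compound 3 `O=C(NCc1ccc([S+]([O-])C2CCN(C3CCOCC3)CC2)cc1)c1cc2ccncc2o1` gives 156000 nM

Compound 1 holds the middle of these three numbers, above compound 2 and under compound 3. Compound 4 `CC(C)n1cc(S(=O)(=O)c2ccc(CNC(=O)c3cc4ccncc4o3)cc2)cn1` differs from compound 1 by 1-isopropyl-1H-pyrazol-4-yl in place of 3,5-difluorophenyl on a sulfonyl sulfur, with 1-isopropyl-1H-pyrazol-4-yl in place of 3,5-difluorophenyl on a sulfonyl sulfur as the counted change. For the measured compounds named here, the step of a 3.7-fold lower number from compound 1 to compound 2 (0.57 log units; beyond the scatter) is the only single-place step measured. It is modest but beyond the scatter, and it lies on a carbonyl carbon, so it shows how far one exchange can move the number but gives no direction for a change on the sulfonyl sulfur. The only hint of direction comes from compound 3, which carries no 3,5-difluorophenyl and gives 156000 nM but also differs from compound 1 elsewhere. A modest rise is therefore expected, with wide uncertainty. The estimated shift is a 3.1-fold higher number from compound 1 to compound 4 (0.48 log units; beyond the scatter) in the upward direction. For compound 4 the expected value is 18000 nM with 6000 nM to 60000 nM as the estimated range.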

Compound 4, solubility: 12000 nM
Beside the measured number, compound 4's estimate is 1.5-fold (0.18 log units) above it; the measured number falls inside the stated range.
By their numbers in this assay, from the lowest: compound 2; then compound 1; then compound 4; then compound 3.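

At the sulfonyl sulfur, this assay now has its first reading from a change in one place: a 2.0-fold higher number from compound 1 to compound 4 (0.31 log units; beyond the scatter). This shows that the number responds to the group on the sulfonyl sulfur, and that the exchange of 3,5-difluorophenyl for 1-isopropyl-1H-pyrazol-4-yl, which takes the count of hydrogen-bond acceptors in that group from 0 to 2, goes upward, by a modest step beyond the scatter. No measurement at hand accounts for this rise.

The compounds shown do not separate the contribution of the five-membered ring from that of its isopropyl group, and they leave open whether the same exchange would read alike on the core of compound 2. From the compounds shown here alone, how a carboxylic acid or a simple methyl group on the sulfonyl sulfur would read in this assay also remains open.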